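The source may hold more compounds than are shown below. What is called first, only, known or untested is meant among the compounds shown, and "the series" means these compounds.

Measured in a functional assay on HCT-15 cells (Homo sapiens) for cytotoxicity, read by ELISA, with a stated time of 4 days; on this read-out higher numbers stand for weaker inhibition and lower numbers for stronger inhibition:
- compound 1 `Clc1ccc(-c2cc(-c3ccoc3)cc(-c3ccco3)n2)s1`: 1280 nM
- compound 2 `Cc1ccc(-c2cc(-c3ccoc3)cc(-c3ccc(Cl)s3)n2)cc1`: 1170 nM
- compound 3 `Clc1ccc(-c2cc(-c3ccco3)nc(-c3ccc(Cl)s3)c2)o1`: > 50000 nM (a limit, not a number)

Compound 3 is the only one of the three that gives a limit and no number (the limit of > 50000 nM in this assay, at which 1 of the 3 values shown sits). The next change leads to compound 4 `Cc1ccc(-c2cc(-c3ccc(Cl)o3)cc(-c3ccc(Cl)s3)n2)cc1`, with 4-methylphenyl in place of furan-2-yl on an aromatic carbon.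

Going by the values given here, two measured steps bear on it. The same exchange, made with furan-3-yl in the molecule, gave a 1.1-fold lower number from compound 1 to compound 2 (0.04 log units; within the scatter), which is within the scatter. The large step is an at least 39-fold higher number from compound 1 to compound 3 (1.59 log units; beyond the scatter), which came with 5-chlorofuran-2-yl in place of furan-3-yl, and compound 4 keeps that 5-chlorofuran-2-yl group. The exchange itself is therefore not expected to move the number in this assay beyond the scatter, and compound 4 is expected to stay close to compound 3. However, the only evidence for the exchange comes from a molecule without the 5-chlorofuran-2-yl group, so a modest drop remains possible, and the assay may again report only a limit.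

The expected step is an at least 1.2-fold lower number from compound 3 to compound 4 (0.09 log units; that floor lies within the scatter). For compound 4 the estimated value is 40000 nM, with an expected range of 4000 nM to 100000 nM.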

Compound 4, half-maximal inhibitory concentration: > 50000 nM
Compound 4: only a limit was reported; the forecaster's own chance of this, stated with the estimate: 60%; at least 1.2-fold (0.09 log units) between middle value and limit.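

In this assay, 5-chlorofuran-2-yl in place of furan-3-yl now has a second instance, on the core carrying 4-methylphenyl, with an at least 42-fold higher number from compound 2 to compound 4 (1.63 log units; beyond the scatter), so the loss is not confined to the core of compound 1: the same change on two cores in this assay, an at least 39-fold higher number (1.59 log units; beyond the scatter) from compound 1 to compound 3 and an at least 42-fold higher number (1.63 log units; beyond the scatter) from compound 2 to compound 4; the limit leaves it open whether they differ. Compound 4 gives > 50000 nM, which is a limit of the assay and not a number. Compound 3 also sits at a limit, so the step for 4-methylphenyl in place of furan-2-yl next to the ring nitrogen cannot be read with 5-chlorofuran-2-yl present, and this exchange adds no readable difference in that setting: the limit of > 50000 nM in this assay, at which 2 of the 4 values shown sit.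

As far as these compounds go, it remains open whether the exchange stays as small in that setting as in a 1.1-fold lower number from compound 1 to compound 2 (0.04 log units; within the scatter), since neither compound with 5-chlorofuran-2-yl gives a number. From the compounds shown here alone, it is also open whether the loss follows the chlorine or the change from furan-3-yl to a furan-2-yl attachment, and an unsubstituted furan-2-yl or a 5-aminofuran-2-yl group at that place would separate the two.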